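Swapping thiophen-2-yl for 4-acetamidophenyl on a sulfonyl sulfur

The source may hold more compounds than are shown below. What is called first, only, known or untested is meant among the compounds shown, and "the series" means these compounds.

Measured so far in a functional assay on MDA-MB-231 cells (Homo sapiens) for antiproliferative activity, read by sulforhodamine B assay, with a stated time of 72 h; on this read-out higher numbers stand for weaker inhibition and lower numbers for stronger inhibition
Compound 1 `CC(=O)Nc1ccc(S(=O)(=O)Nc2cc(SCC(=O)N[C@@H](CC(C)C)B(O)O)c(O)c3ccccc23)cc1` gives 4450 nM
Compound 2 `CC(C)C[C@H](NC(=O)C(C)Sc1cc(NS(=O)(=O)c2ccc(Cl)cc2)c2ccccc2c1O)B(O)O` gives 6150 nM; 6460 nM (2 entries)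
Compound 3 `CC(C)C[C@H](NC(=O)C(C)Sc1cc(NS(=O)(=O)c2cccs2)c2ccccc2c1O)B(O)O` gives 7450 nM

Compound 3 at 7450 nM lies within the usual scatter of compound 1 at 4450 nM. Compound 4 `CC(=O)Nc1ccc(S(=O)(=O)Nc2cc(SC(C)C(=O)N[C@@H](CC(C)C)B(O)O)c(O)c3ccccc23)cc1` carries 4-acetamidophenyl in place of thiophen-2-yl on a sulfonyl sulfur. Going by the values given here, no measured pair shows a change of this kind on its own, so the expectation rests on how closely the values sit, with compound 2 at 6150 nM; 6460 nM (2 entries) also within the scatter of the other two. The estimated 1.3-fold lower number from compound 3 to compound 4 (0.11 log units; within the scatter) in this assay is expected to stay within the scatter, leaning slightly towards a lower number. For compound 4 the expected value is 5800 nM, with an estimated range from 2800 nM to 12000 nM.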

Compound 4, half-maximal inhibitory concentration: 2800 nM
The estimate for compound 4 lay 2.1-fold (0.32 log units) above the measured number; the range from low to high includes it.
By their numbers in this assay, from the lowest: compounds 4, 1 and 3 (each within the scatter of the next, the first and the last beyond it).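

In this assay, going by these compounds alone, 4-acetamidophenyl in place of thiophen-2-yl on a sulfonyl sulfur gives a 2.7-fold lower number from compound 3 to compound 4 (0.42 log units; beyond the scatter) and so provides the first modest step at this position, which no earlier pair could show. The methyl in place of hydrogen on a saturated chain carbon bound to a carbonyl carbon and a sulfur gives a 1.6-fold lower number from compound 1 to compound 4 (0.20 log units; within the scatter) and so leaves no readable change at that place. The compounds shown leave open how an amine or a carboxylic acid in place of the acetamido group would read in this assay and whether a longer chain in place of that methyl would alter the number. Nothing measured here gives a reason for the step from thiophen-2-yl to 4-acetamidophenyl.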